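Series notes: amide variation on a shared benzimidazole-type core

This account rests on a few compounds, and the source may have more. Where it says the series, first, only, none or still open, it means among the compounds named here.

For compound 1 `CCCCCC(=O)Nc1cc2nc(C3CCCCC3)[nH]c2cc1N(CC)CC` the entry in an ADME assay on Vero cells (Chlorocebus sabaeus) for cytotoxicity, read by resazurin assay, with a stated time of 3 days (a higher number here means a weaker inhibitor, a lower number a stronger inhibitor), is "not determined" (no result reported). Compound 2 `CCN(CC)c1cc2[nH]c(C3CCCCC3)nc2cc1NC(=O)c1ccc(OC(F)F)cc1` sits at a limit of the assay: in this assay compound 2 gives > 100 ug/mL. Compound 3 `C=Cc1cccc(C(=O)Nc2cc3nc(C4CCCCC4)[nH]c3cc2N(CC)CC)c1` likewise sits at a limit: in this assay compound 3 gives > 100 ug/mL. The step from compound 2 to compound 3, a step that the two limits leave unreadable from compound 2 to compound 3, therefore cannot be sized. So compound 3 stands at the limit, with two of three entries there (the limit of > 100 ug/mL in this assay, at which 2 of the 3 values shown sit).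

Compound 4 `CCCNC(=O)Nc1cc2nc(C3CCCCC3)[nH]c2cc1N(CC)CC` differs from compound 3 by propylamino in place of 3-vinylphenyl on a carbonyl carbon. Among the measured compounds shown here, no measured step bears on this change with a readable size; the only step available is unreadable, and nothing beyond the two limits exists in this assay. The step from compound 3 to compound 4 is therefore expected to be a number no higher from compound 3 to compound 4 (the limit leaves the size open), none beyond the scatter. Compound 4 is expected to give 100 ug/mL in this assay, in a range from 50 ug/mL to 200 ug/mL, most likely reported again as a limit.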

Compound 4, half-maximal inhibitory concentration: > 100 ug/mL
Compound 4 was reported as a limit (the forecaster's own chance of this, stated with the estimate: 80%); the middle value lies on the limit itself.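

In this assay compound 4 gives > 100 ug/mL, a limit and not a number. No step among compound 2, compound 3 and compound 4 can be read: the limit of > 100 ug/mL in this assay, at which 3 of the 4 values shown sit.

The compounds shown leave open whether any change on the carbonyl carbon shifts the value at all.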